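Notes on the step from compound 1 to compound 3

The source may hold more compounds than are shown below. What is called first, only, known or untested is meant among the compounds shown, and "the series" means these compounds.

Read so far in a functional assay on MOLT-4 cells (Homo sapiens) for antiproliferative activity, with a stated time of 48 h; on this read-out higher numbers stand for weaker inhibition and lower numbers for stronger inhibition
- compound 1 `C=C(Br)C(=O)Nc1ccc(/C=C/C(=O)c2ccc(F)cc2)cc1` gives 660 nM
- compound 2 `C=C(Br)C(=O)Nc1ccc(/C=C/C(=O)c2ccc(Cl)c(Cl)c2)cc1` gives 1800 nM

Compound 1 holds the lower of the two numbers, with compound 2 nearest to it. Next is compound 3 `C=C(Br)C(=O)Nc1ccc(/C=C/C(=O)c2ccc(OC)cc2)cc1` which carries methoxy in place of fluoro on an aromatic carbon, para to a large group (methoxy in place of fluoro on an aromatic carbon). Within the data shown here, the only measured step (a 2.7-fold higher number from compound 1 to compound 2 (0.44 log units; beyond the scatter)) is modest and also replaces the 4-fluorophenyl group, but it gives no direct reading on methoxy. A step no larger than that is expected in this assay in either direction, possibly none beyond the scatter. The expected move is a 1.2-fold higher number from compound 1 to compound 3 (0.08 log units; within the scatter) as an estimate only. For compound 3 the estimated value is 800 nM with a range from 300 nM to 2200 nM for now.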

Compound 3, half-maximal inhibitory concentration: 1300 nM
For compound 3 the middle estimate is 1.6-fold (0.21 log units) below the measured one; low and high end bracket the measured number.
By their numbers in this assay, from the lowest: compounds 1, 3 and 2 (each within the scatter of the next, the first and the last beyond it).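

In this assay, among these compounds, methoxy in place of fluoro gives the first reading of a non-halogen group at this position (a 2.0-fold higher number from compound 1 to compound 3 (0.29 log units; within the scatter)). The 4-methoxyphenyl compound also cannot be separated from the 3,4-dichlorophenyl compound (a 1.4-fold lower number from compound 2 to compound 3 (0.14 log units; within the scatter)), so compound 3 lies within the scatter of both earlier compounds, although those two differ beyond it. No supporting data bear on the reason for this result.

From the compounds shown here alone, whether an amine, a carboxylic acid or a longer alkoxy chain at this position would stay in the same range remains open.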